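From 4-bromophenyl to 3-methoxyphenyl: an expected tolerance

The source may report more compounds than this note shows. Statements on the series, on what has been measured and on what is new or still open speak of the compounds shown alone.

Compound 1 `Cn1c(-c2ccccc2)cnc1NC(=O)c1ccc(F)cc1`: > 100000 nM, a limit
Compound 2 `Cn1c(-c2ccccc2Cl)cnc1NC(=O)c1ncc[nH]1`: > 50000 nM, a limit
Compound 3 `Cn1c(-c2ccc(Br)cc2)cnc1NC(=O)c1ccc(F)cc1`: 46000 nM

Among the measured compounds shown here, in a toxicity assay on THP-1 cells (Homo sapiens) for inhibition (a lower number here means that less compound is tolerated, a higher number that more compound is tolerated), compound 3 gives 46000 nM, the only true number of the three. The values of compound 1 and compound 2 are limits. Compound 4 `COc1cccc(-c2cnc(NC(=O)c3ccc(F)cc3)n2C)c1` differs from compound 3 by one change: 3-methoxyphenyl in place of 4-bromophenyl on an aromatic carbon. For the measured compounds named here, one measured step bears on this, an at least 2.1-fold lower number from compound 1 to compound 3 (0.33 log units; beyond the scatter), the step that adds bromo. Going by the values given here, compound 4 carries no bromo, so that step suggests a move back toward a higher number, but no measured compound carries 3-methoxyphenyl. The expected step is a 1.3-fold higher number from compound 3 to compound 4 (0.12 log units; within the scatter), a small one toward a higher number. For compound 4 the estimated value is 60000 nM, with an expected range of 25000 nM to 130000 nM.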

Compound 4, half-maximal cytotoxic concentration: > 100000 nM
Compound 4: only a limit was reported; the forecaster's own chance of this, stated with the estimate: 45%; middle value at least 1.6-fold (0.22 log units) away from the limit.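

The change to 3-methoxyphenyl gives an at least 2.1-fold higher number from compound 3 to compound 4 (0.33 log units; beyond the scatter), so the lower number seen with 4-bromophenyl does not carry over to every substituted phenyl group at this position. In this assay compound 4 gives > 100000 nM, which is a limit of the assay: the limit of > 100000 nM in this assay, at which 2 of the 4 values shown sit. The steps between compound 1 and compound 4 cannot be read, as both values are limits.

What the compounds shown leave open is how far the lower number depends on bromo itself or on where it sits, which 3-bromophenyl and 4-methoxyphenyl would separate. From the compounds shown here alone, how an amine or a carboxylic acid on this phenyl ring would read here also stays open.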